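Chloro to bromo in a series with no spread

A few compounds are considered here, and "the series" means these few. Any claim that something is new, unique, unknown or untested is made for them only; others in the source may bear on it.

compound 1 `CSc1ccc(/C=C(\C(=O)c2ccc(Br)cc2)S(=O)(=O)Cc2ccc(F)cc2)cc1`: 50000 nM
compound 2 `Cc1ccc(/C=C(\C(=O)c2ccc(Cl)cc2)S(=O)(=O)Cc2ccc(F)cc2)s1`: 50000 nM
compound 3 `O=C(/C(=C\c1c[nH]c2ccccc12)S(=O)(=O)Cc1ccc(F)cc1)c1ccc(Cl)cc1`: 50000 nM

In a functional assay on DU-145 cells (Homo sapiens) for inhibition, read by trypan blue exclusion, with a stated time of 96 h (a lower number here means a stronger inhibitor of growth, a higher number a weaker inhibitor of growth), compound 2 gives 50000 nM and stands level with compound 1 and compound 3, so the three values show no spread. The next compound is compound 4 `Cc1ccc(/C=C(\C(=O)c2ccc(Br)cc2)S(=O)(=O)Cc2ccc(F)cc2)s1`, which differs from compound 2 by a single substituent: bromo in place of chloro on an aromatic carbon. The swap sits on the 4-chlorophenyl group, which becomes 4-bromophenyl.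

Among the compounds with values here, no measured pair tests this exact swap. Within the data shown here, the one measured step, no change at the digits printed from compound 2 to compound 3 (within the scatter), exchanges a whole ring group and is no larger than the scatter. Compound 1 already carries the 4-bromophenyl group and gives 50000 nM in this assay as well. On this evidence, no shift beyond the scatter is expected in either direction. The expected size is no change at the digits printed from compound 2 to compound 4 (within the scatter) in this estimate. For compound 4 the estimated value is 50000 nM with an expected range from 20000 nM to 80000 nM in this assay.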

Compound 4, concentration for 50% growth inhibition: 1000 nM
For compound 4 the middle estimate is 50-fold (1.70 log units) above the measured one; the measured number lies below the stated range.
By their numbers in this assay, from the lowest: compound 4; then compounds 1, 2 and 3 (each within the scatter of the next).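

In this assay, within the data shown here, the halogen on this ring matters: bromo in place of chloro on an aromatic carbon gives a 50-fold lower number from compound 2 to compound 4 (1.70 log units; beyond the scatter) and so lifts compound 4 clear of the flat level of the earlier compounds. The 4-bromophenyl group is not enough alone, since compound 1 carries it too, and 5-methylthiophen-2-yl in place of 4-(methylsulfanyl)phenyl gives a 50-fold lower number from compound 1 to compound 4 (1.70 log units; beyond the scatter) in that setting. Among these compounds, then, the low number appears only when bromo and the 5-methylthiophen-2-yl group occur together, and nothing available explains this result.

From the compounds shown here alone, it remains open whether iodo or a nitrile at the same place on the ring would keep or extend the gain. Whether the 1H-indol-3-yl group of compound 3 would respond to bromo in the same way is also unknown.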